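Azaindole-ether naphthyridinone amides: N-aryl swap on a fluorinated core

The compounds below may be only part of what the source reports. "The series", "measured", "known", "first", "only" and "open" are said of these compounds alone.

Three compounds in the series are measured in a functional assay on A549 cells (Homo sapiens) for antiproliferative activity, read by MTT assay, with a stated time of 72 h; a lower number here means a stronger inhibitor, a higher number a weaker inhibitor. Compound 1 `O=C(Nc1ccc(Oc2ccnc3[nH]ccc23)cc1)c1cc2cccnc2n(-c2ccc(F)c(Cl)c2)c1=O` gives 680 nM in this assay. Compound 2 `O=C(Nc1ccc(Oc2ccnc3[nH]ccc23)cc1)c1cc2cccnc2n(-c2ccc(Br)cc2F)c1=O` carries 4-bromo-2-fluorophenyl in place of 3-chloro-4-fluorophenyl on an aromatic nitrogen and gives 1570 nM; the step is a 2.3-fold higher number from compound 1 to compound 2 (0.36 log units; beyond the scatter). The core of compound 3 differs from that of compound 1 in a way not broken down here. Compound 3 `Cn1ccc2c(Oc3ccc(NC(=O)c4cc5cccnc5n(-c5ccc(F)c(Cl)c5)c4=O)cc3F)ccnc21` gives 3560 nM in this assay, the highest of the three numbers, and its steps to compound 2 and to compound 1 both lie beyond the scatter.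

Compound 4 `Cn1ccc2c(Oc3ccc(NC(=O)c4cc5cccnc5n(-c5ccc(Br)cc5F)c4=O)cc3F)ccnc21` is not yet measured. It stands to compound 3 as compound 2 stands to compound 1: 4-bromo-2-fluorophenyl in place of 3-chloro-4-fluorophenyl on an aromatic nitrogen. The place of the change is described in the same words for both pairs, so the change is the same one made on a different core. Within the data shown here, the only measured instance of this change is the step from compound 1 to compound 2, which raises the number by a modest margin beyond the scatter. With one instance only, and on a core whose difference from that of compound 1 is not broken down, the transfer is uncertain, but there is nothing in the series to argue against it.

Compound 4 is therefore expected to show a step of a 2.2-fold higher number from compound 3 to compound 4 (0.35 log units; beyond the scatter) in this assay, resting on the step of a 2.3-fold higher number from compound 1 to compound 2 (0.36 log units; beyond the scatter). The estimate for compound 4 is 8000 nM, with an expected range from 3500 nM to 20000 nM.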

Compound 4, half-maximal inhibitory concentration: 2690 nM
The estimate for compound 4 lay 3.0-fold (0.47 log units) above the measured number, and the stated range ends above it.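

On the core of compound 3, in this assay, 4-bromo-2-fluorophenyl in place of 3-chloro-4-fluorophenyl gives a 1.3-fold lower number from compound 3 to compound 4 (0.12 log units; within the scatter), so the two aryl groups are not separated on this core. Among these compounds, the step seen on the core of compound 1 therefore does not carry over in size to the core of compound 3, and the two instances disagree: the same change on two cores in this assay, a 2.3-fold higher number (0.36 log units; beyond the scatter) from compound 1 to compound 2 and a 1.3-fold lower number (0.12 log units; within the scatter) from compound 3 to compound 4, 3.1-fold (0.49 log units) apart, beyond the scatter of two such steps This shows that, across these two cores, the aryl swap cannot be treated as a fixed increment, but with only one pair on each core it does not show which feature of the core difference goes with the disagreement, nor how the swap would behave on any further core.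

The compounds shown leave open which of the differences between the core of compound 1 and that of compound 3 matters, as no compound here carries only one of them. Also open, going by these compounds, is how an unsubstituted phenyl, a pyridine ring or a simple ethyl chain on the aromatic nitrogen would read on each of the two cores, which would show whether the disagreement extends beyond this one pair of aryl groups.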